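Shortening the ring nitrogen substituent from cyclohexyl to ethyl

The source may hold more compounds than are shown below. What is called first, only, known or untested is meant among the compounds shown, and "the series" means these compounds.

Compound 3 `O=c1c(S(=O)(=O)c2ccc(F)cc2F)cc2cnc(Nc3ccc4[nH]ccc4c3)nc2n1C1CCCCC1` stands second highest of the three numbers in a functional assay on DU-145 cells (Homo sapiens) for inhibition, read by trypan blue exclusion, with a stated time of 72 h (a higher number here means a weaker inhibitor, a lower number a stronger inhibitor), where compound 3 gives 10000 nM. Compound 2 `O=c1[nH]c2nc(Nc3ccc4[nH]ccc4c3)ncc2cc1S(=O)(=O)c1ccc(F)cc1F` gives 15000 nM in this assay, and compound 1 `CCCn1c(=O)c(S(=O)(=O)c2ccc(F)cc2F)cc2cnc(Nc3ccc4[nH]ccc4c3)nc21` gives 1000 nM. Compound 4 `CCn1c(=O)c(S(=O)(=O)c2ccc(F)cc2F)cc2cnc(Nc3ccc4[nH]ccc4c3)nc21` differs from compound 3 in one place: ethyl in place of cyclohexyl on an aromatic nitrogen. Among the compounds with values here, the steps that bear on it are a 10-fold higher number from compound 1 to compound 3 (1.00 log units; beyond the scatter) and a 1.5-fold lower number from compound 2 to compound 3 (0.18 log units; within the scatter), with a 15-fold higher number from compound 1 to compound 2 (1.18 log units; beyond the scatter) showing that hydrogen also gives a high number. Ethyl is a short chain like propyl, so a large drop in the number is expected for compound 4 because a 10-fold higher number from compound 1 to compound 3 (1.00 log units; beyond the scatter) went the other way. Compound 4 is estimated at 1500 nM, within 500 nM to 5000 nM. The expected step is a 6.7-fold lower number from compound 3 to compound 4 (0.82 log units; beyond the scatter).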

Compound 4, half-maximal inhibitory concentration: 750 nM
Compound 4: middle estimate off by 2.0-fold (0.30 log units), on the high side; measured number inside the range.
By their numbers in this assay, from the lowest: compounds 4 and 1 (each within the scatter of the next); then compounds 3 and 2 (each within the scatter of the next).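

In this assay, ethyl and propyl on this aromatic nitrogen cannot be told apart (with a 1.3-fold lower number from compound 1 to compound 4 (0.12 log units; within the scatter)). Ethyl instead separates clearly from cyclohexyl (with a 13-fold lower number from compound 3 to compound 4 (1.12 log units; beyond the scatter)) and from hydrogen (with a 20-fold lower number from compound 2 to compound 4 (1.30 log units; beyond the scatter)), so among these compounds both short chains give low numbers, while the ring and the unsubstituted nitrogen give high numbers. Nothing measured here accounts for these steps.

The compounds shown leave open whether methyl, a longer chain such as butyl, or a chain bearing an amine would keep the number low. They also leave open how a smaller ring such as cyclopropyl would compare with cyclohexyl.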